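Fluoro substitution on a chromone core and growth inhibition

The source may hold more compounds than are shown below. What is called first, only, known or untested is meant among the compounds shown, and "the series" means these compounds.

Measured compounds:
compound 1 `O=c1c(C2N=C(c3ccccc3)SS2)coc2ccc(F)cc12`, 37%
compound 2 `O=c1c(C2N=C(c3ccccc3)SS2)coc2ccccc12`, 18%
compound 3 `O=c1c(C(=S)Nc2ccccc2)coc2ccccc12`, 71%

In a functional assay on COLO 205 cells (Homo sapiens) for inhibition, read by sulforhodamine B assay, with a stated time of 48 h, tested at 100 uM (a higher number here means more inhibition of growth at the concentration tested, a lower number less inhibition of growth), compound 3 gives 71%, the highest number of the three. The difference between the core of compound 3 and the core of compound 2 is not broken down here. Within the other core, one change has been measured: fluoro in place of hydrogen on an aromatic carbon. Its step was a number 19 percentage points higher from compound 2 to compound 1 (beyond the scatter). Compound 4 `O=c1c(C(=S)Nc2ccccc2)coc2ccc(F)cc12` is not yet measured; it carries the same change on its own core: fluoro in place of hydrogen on an aromatic carbon.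

Resting on that single measured step, compound 4 is expected to sit above compound 3 by a step of about a number 9 percentage points higher from compound 3 to compound 4 (within the scatter), since compound 3 already starts from 71% and the read-out cannot exceed complete inhibition. The estimate for compound 4 in this assay is 80%, with an expected range from 65% to 95%.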

Compound 4, percent growth inhibition at one concentration: 26%
Compound 4: the middle estimate sits 54 percentage points above what was measured; measured number below the stated range.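

In this assay, fluoro in place of hydrogen on an aromatic carbon gave a number 45 percentage points lower from compound 3 to compound 4 (beyond the scatter), the opposite direction to its effect on the other core, so the step measured on one core did not carry over to the other: the same change on two cores in this assay, a number 19 percentage points higher (beyond the scatter) from compound 2 to compound 1 and a number 45 percentage points lower (beyond the scatter) from compound 3 to compound 4, 64 percentage points apart, beyond the scatter of two such steps. In this series, then, the effect of this change depends on the core that carries it. For the compounds shown here, the pair of steps does not show what underlies the reversal, and it rests on only two cores, one position and a single tested concentration.

The compounds shown leave open whether another group at this position, such as chloro, methoxy or an amine, would also move the two cores in opposite directions. They also leave open whether the reversal would hold at other concentrations.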